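Permeability of a quinoline-type series: a saturated side group swap

The source may hold more compounds than are shown below. What is called first, only, known or untested is meant among the compounds shown, and "the series" means these compounds.

Of the compounds shown here, three of a shared core have been measured in an ADME assay for permeability, using PAMPA, with a stated time of 30 min, at pH 7.4; on this read-out lower numbers stand for lower permeability and higher numbers for higher permeability. Compound 1 `COc1cccc(Oc2ccc3c(NCCCNCc4cccc(OC)c4O)ccnc3c2)c1` gives 317 10^-6 cm/s. Compound 2 `CCC(CC)c1ccc2c(NCCCNCc3cc(F)ccc3OC)ccnc2c1` gives 23 10^-6 cm/s, and compound 3 `CCC(CC)c1ccc2c(NCCCNCc3ccco3)ccnc2c1` gives 23 10^-6 cm/s. Compound 2 thus stands level with compound 3 at the digits printed, the two together the lowest of the three numbers, while compound 1 sits furthest away with a markedly higher number. Within the data shown here, the one step measured between compounds that differ in a single place is no change at the digits printed from compound 2 to compound 3 (within the scatter), a change on the saturated chain carbon bound to an amine nitrogen that left the read-out within the scatter.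

Compound 4 `COc1ccc(F)cc1CNCCCNc1ccnc2cc(CC3CCCCC3)ccc12` has not yet been measured. It differs from compound 2 in this way: cyclohexylmethyl in place of pentan-3-yl on an aromatic carbon

Among the measured compounds shown here, no measured step touches the group on that aromatic carbon, so the only guidance is that the one recorded change elsewhere in the molecule, from compound 2 to compound 3, was flat. Both the leaving and the entering group are saturated hydrocarbon with no donors, acceptors or charge. Compound 4 is therefore expected to show a step of no change at the digits printed from compound 2 to compound 4 (within the scatter), that is, none beyond the scatter. The estimated value for compound 4 is 23 10^-6 cm/s, with a range from 10 10^-6 cm/s to 55 10^-6 cm/s.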

Compound 4, apparent permeability: 23 10^-6 cm/s
Estimate against measurement, compound 4: no gap at the digits printed; measured number inside the range.
By their numbers in this assay, from the lowest: compounds 2, 3 and 4 (each within the scatter of the next); then compound 1.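

In this assay, among these compounds, the change on the aromatic carbon gives no change at the digits printed from compound 2 to compound 4 (within the scatter); this is the first measured single change at this position, as the earlier step concerned only a saturated chain carbon bound to an amine nitrogen. On this pair, cyclohexylmethyl, with 7 heavy atoms and one six-membered non-aromatic ring of carbon only, stands in place of pentan-3-yl, with 5 heavy atoms and no ring, and the read-out stays within the scatter. No measured finding is available to explain this result.

From the compounds shown here alone, both groups in this pair consist of carbon only and have no hydrogen-bond donors or acceptors, so it remains open whether an amine, a carboxylic acid or a hydroxyl group on the same aromatic carbon would also leave the read-out within the scatter. Compound 1, at 317 10^-6 cm/s, differs from the other compounds in more than one place, so its number cannot be tied to any single group, and the steps that would separate those changes cannot be read.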